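Removing One Methyl from Compound 1

The source may report more compounds than this note shows. Statements on the series, on what has been measured and on what is new or still open speak of the compounds shown alone.

Two related compounds have readings so far. In an ADME assay, in the presence of a further agent that is not named here, compound 1 (`Cc1c(Cn2ccnc2)sc2ccc(C(=O)O)cc12`) gives 6.04 as its reading, and compound 2 (`Cc1c(Cn2ccnc2)n(C)c2ccc(C(=O)O)cc12`) gives 6.32 as its reading. These two values lie within the scatter of each other, so compound 1 cannot be placed above or below compound 2.

Still awaiting measurement is compound 3 (`O=C(O)c1ccc2sc(Cn3ccnc3)cc2c1`). It differs from compound 1 in one place: hydrogen in place of methyl on an aromatic carbon. Among the measured compounds shown here, no measured pair shows what this kind of swap does in this assay so any expectation here has little direct support. The starting point is compound 1 at 6.04 as the closest measured structure, and no shift beyond the scatter is expected. The estimated change is a number 0.04 log units lower from compound 1 to compound 3 (within the scatter) and it would be too small to tell apart from repeat variation. For compound 3 the expected value is 6 with an estimated range from 5.7 to 6.3 in this measurement.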

Compound 3, acid dissociation constant: 6.58
Compound 3: the middle estimate sits 0.58 log units below what was measured; measured number outside the range, above it.
By their numbers in this assay, from the lowest: compounds 1, 2 and 3 (each within the scatter of the next, the first and the last beyond it).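

In this assay, hydrogen in place of methyl on this aromatic carbon of the five-membered aromatic ring with 1 sulfur, next to the ring atom that bears the (1H-imidazol-1-yl)methyl group, gives a number 0.54 log units higher from compound 1 to compound 3 (beyond the scatter). Among the compounds shown here, this is the first pair here that differs in only one place, and it gives the first direct sign that this position matters for the reading: losing a methyl, a single heavy atom, is enough to move the number past the usual scatter of repeat measurements. No measurement at hand gives a reason for the direction or the size of this step.

Still open, on these data alone, is what other groups on this same aromatic carbon would do: an ethyl group, a chlorine atom or a methoxy group could show whether the reading follows any trend across substituents there, or whether the step is particular to the swap of methyl for hydrogen. As far as these compounds go, it is also open whether the same swap would give a similar step on another core, since this single pair comes from the core of compound 1 alone.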